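Working notes: hydroxy in place of fluoro, compound 1 to compound 3

The source may hold more compounds than are shown below. What is called first, only, known or untested is meant among the compounds shown, and "the series" means these compounds.

Measured so far:
compound 1, `COc1ccc(C2=C(c3cc(OC)c(OC)c(OC)c3)C(=O)C(OC(C)=O)C2)cc1F`: < 1 ug/mL
compound 2, `COc1ccc(C2=C(c3cc(OC)c(OC)c(OC)c3)CC(O)C2=O)cc1[N+](=O)[O-]`: > 100 ug/mL

Both values come from an ADME assay on HEp-2 cells (Homo sapiens) for cytotoxicity, read by MTT assay, with a stated time of 72 h; a lower number here means a stronger inhibitor, a higher number a weaker inhibitor. For compound 1 the value < 1 ug/mL is a limit of this assay, not a number; this is the limit of < 1 ug/mL in this assay, at which 1 of the 2 values shown sits. For compound 2 the value > 100 ug/mL is likewise a limit and not a number; this is the limit of > 100 ug/mL in this assay, at which 1 of the 2 values shown sits. Going by the values given here, compound 2 differs from compound 1 in more than one place, so no single step between them is defined; the two values only show that compound 1 sits at the strong limit and compound 2 at the weak limit. Compound 1 therefore stands at the lowest value this assay reports.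

Compound 3, `COc1ccc(C2=C(c3cc(OC)c(OC)c(OC)c3)C(=O)C(OC(C)=O)C2)cc1O`, is not yet measured. It differs from compound 1 by hydroxy in place of fluoro on an aromatic carbon. Among the compounds with values here, with no step between measured compounds to lean on, the change from compound 1 to compound 3 is expected to give no shift in this assay beyond the scatter, and compound 3 is expected to remain at or near the strong limit.

For compound 3 in this assay the estimate is 0.5 ug/mL, with a range from 0.1 ug/mL to 3 ug/mL, corresponding to an expected step that the limit leaves unreadable from compound 1 to compound 3.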

Compound 3, half-maximal inhibitory concentration: > 100 ug/mL
Compound 3: no number, only a limit; the forecaster's own chance of this, stated with the estimate: 60%; at least 200-fold (2.30 log units) between middle value and limit.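

In this assay, hydroxy in place of fluoro on an aromatic carbon, ortho to a methoxy group, gives an at least 100-fold higher number from compound 1 to compound 3 (2.00 log units; beyond the scatter), the only single-place step shown in the series. Compound 3 gives > 100 ug/mL, which is a limit of the assay and not a number: the limit of > 100 ug/mL in this assay, at which 2 of the 3 values shown sit. The change from 3-fluoro-4-methoxyphenyl to 3-hydroxy-4-methoxyphenyl thus shows that this one aromatic position, with the rest of the structure unchanged, can decide the read-out, something compound 1 and compound 2 could not show, as they differ in more than one place.

Open, going by these compounds, is whether the loss belongs to hydroxy in particular or would also follow chloro, an amine or plain hydrogen on this carbon. Equally open, on these data alone, is the true size of the step, whose two ends are both limits, so that only its printed bound can be read.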